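The compounds below may be only part of what the source reports. "The series", "measured", "known", "first", "only" and "open" are said of these compounds alone.

Working notes on the series. In a functional assay on HL-60 cells (Homo sapiens) for cytotoxicity, read by MTT assay, with a stated time of 72 h (on this read-out higher numbers stand for weaker inhibition and lower numbers for stronger inhibition), compound 1 `CO[C@H]1C[C@@]2(CC[C@@]3(O2)[C@H](C)CC[C@H]2C(C)(C)[C@@H](OC(C)=O)CC[C@@]23C)[C@H](OC)O1` gives < 5 ug/mL, which is a limit and not a number. Compound 2 `C[C@@H]1C[C@@H](O)[C@H]2C(C)(C)CCC[C@]2(C)[C@@]12CC[C@]1(COC(=O)C1)O2` gives < 5 ug/mL, also a limit. Both values sit at the limit of < 5 ug/mL in this assay, at which 2 of the 2 values shown sit, so the position of compound 1 is bounded on one side only, and no order can be set between the two compounds.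

Compound 3 `CO[C@@H]1C[C@@]2(CC[C@@]3(O2)[C@H](C)CC[C@H]2C(C)(C)[C@@H](OC(C)=O)CC[C@@]23C)[C@H](OC)O1` is the next to be read: the two compounds have the same atoms and bonds and differ only in configuration as drawn: 1 of 8 stereo elements differ; a stereocentre at a saturated ring carbon is drawn R in compound 1 and S in compound 3. A stereocentre at a saturated ring carbon is drawn R in compound 1 and S in compound 3. For the measured compounds named here, no measured pair differs in one place, so no step is available as a guide. The expectation rests only on compound 1, whose limit is < 5 ug/mL. In this assay no change beyond the scatter is expected, in either direction, and the expected step is a step that the limit leaves unreadable from compound 1 to compound 3. The estimate for compound 3 is 4 ug/mL, with an expected range of 1.5 ug/mL to 10 ug/mL.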

Compound 3, half-maximal inhibitory concentration: < 5 ug/mL
Compound 3 gave a limit, no number (the forecaster's own chance of this, stated with the estimate: 65%); the middle value lies beyond the limit too.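

No step can be read from compound 1 to compound 3 in this assay, as both results are limits and not numbers: the limit of < 5 ug/mL in this assay, at which 3 of the 3 values shown sit.

The compounds shown leave open whether the configuration at that saturated ring carbon changes the read-out at all, in either direction.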